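From tert-butyl to cyclohexyl on compound 3

A few compounds are considered here, and "the series" means these few. Any claim that something is new, unique, unknown or untested is made for them only; others in the source may bear on it.

Compounds sharing one core can differ at a single place, here on a saturated chain carbon bound to a carbonyl carbon and an oxygen on a saturated carbon. In a functional assay on a cell-free system (plasma, Homo sapiens), with a stated time of 3 min (a lower number here means a stronger inhibitor, a higher number a weaker inhibitor), compound 1 `Cc1cccc([C@@H](O)C(=O)N2N=CC[C@H]2C(=O)NCc2cc(Cl)ccc2-n2cnnn2)c1` gives 830 nM, compound 2 `CC(C)(C)C[C@@H](O)C(=O)N1N=CC[C@H]1C(=O)NCc1cc(Cl)ccc1-n1cnnn1` gives 590 nM, and compound 3 `CC(C)(C)[C@@H](O)C(=O)N1N=CC[C@H]1C(=O)NCc1cc(Cl)ccc1-n1cnnn1` gives 1400 nM. Compound 3 stands clearly apart from only one of the others, as the two steps show: a 2.4-fold higher number from compound 2 to compound 3 (0.38 log units; beyond the scatter), and a 1.7-fold higher number from compound 1 to compound 3 (0.23 log units; within the scatter).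

Compound 4 `O=C(NCc1cc(Cl)ccc1-n1cnnn1)[C@@H]1CC=NN1C(=O)[C@H](O)C1CCCCC1` has cyclohexyl in place of tert-butyl on a saturated chain carbon bound to a carbonyl carbon and an oxygen on a saturated carbon. Within the data shown here, no measured step involves cyclohexyl, so the guide is how far this place has moved the number so far. The largest step is the modest one to compound 3 from compound 2, and the remaining swap is smaller: a 1.4-fold lower number from compound 1 to compound 2 (0.15 log units; within the scatter). A value close to those of compound 1 and compound 2 therefore seems likely.

The expected change is small and towards a lower number: a 1.9-fold lower number from compound 3 to compound 4 (0.27 log units; within the scatter). For compound 4 the estimated value is 750 nM, with an expected range of 300 nM to 1600 nM.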

Compound 4, half-maximal inhibitory concentration: 970 nM
Estimate against measurement, compound 4: 1.3-fold (0.11 log units) below, within the range that was stated.
By their numbers in this assay, from the lowest: compounds 2, 1, 4 and 3 (each within the scatter of the next, the first and the last beyond it).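

In this assay cyclohexyl is the only saturated ring at this place among these compounds, and it reads within the scatter of all three others, with a 1.4-fold lower number from compound 3 to compound 4 (0.16 log units; within the scatter) and a 1.6-fold higher number from compound 2 to compound 4 (0.22 log units; within the scatter) and a 1.2-fold higher number from compound 1 to compound 4 (0.07 log units; within the scatter) as the steps. Among these compounds, a saturated ring, an aromatic ring and two branched chains therefore give similar numbers here, and the one step beyond the scatter remains a 2.4-fold higher number from compound 2 to compound 3 (0.38 log units; beyond the scatter), which compound 4 now bridges without adding a second such step. No measurement shown accounts for why these groups read so alike.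

Across these carbon-only groups the number stays in a narrow band. Going by these compounds, whether an amine, a carboxylic acid or a longer chain at this place would move it further remains open.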